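Hexylamino in place of methylsulfanyl on the shared core

This account rests on a few compounds, and the source may have more. Where it says the series, first, only, none or still open, it means among the compounds named here.

Among the measured compounds shown here, compound 2 `CSc1ccn([C@@H]2O[C@H](COP(=O)(O)OP(=O)(O)OP(=O)(O)O)[C@@H](O)[C@H]2O)c(=O)n1` gives the lowest of the two numbers so far in a functional assay on cells for agonist activity at P2Y purinoceptor 2 (Homo sapiens), read by inositol phosphate accumulation, with a stated time of 90 min (on this read-out lower numbers stand for an effect already at smaller amounts and higher numbers for an effect only at larger amounts of compound), namely 3100 nM. Its nearest neighbour is compound 1 `CCCCCCOc1ccn([C@@H]2O[C@H](COP(=O)(O)OP(=O)(O)OP(=O)(O)O)[C@@H](O)[C@H]2O)c(=O)n1`, which in this assay gives 489000 nM. For the measured compounds named here, the only measured step, a 160-fold lower number from compound 1 to compound 2 (2.20 log units; beyond the scatter), is large and runs well beyond the scatter. Compound 3 `CCCCCCNc1ccn([C@@H]2O[C@H](COP(=O)(O)OP(=O)(O)OP(=O)(O)O)[C@@H](O)[C@H]2O)c(=O)n1` differs from compound 2 by hexylamino in place of methylsulfanyl on an aromatic carbon. Going by the values given here, no measured step matches this change directly; the step from compound 1 to compound 2 bears on it only in that it shows the hexyl chain of compound 1 going with a much higher number than the methylsulfanyl of compound 2, while the nitrogen now entering is new. The account therefore expects the number to rise, and compound 3 is estimated at 50000 nM, a step of a 16-fold higher number from compound 2 to compound 3 (1.21 log units; beyond the scatter), with a range from 5000 nM to 500000 nM.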

Compound 3, half-maximal effective concentration: 26300 nM
For compound 3 the middle estimate is 1.9-fold (0.28 log units) above the measured one; the measured number falls inside the stated range.
By their numbers in this assay, from the lowest: compound 2; then compound 3; then compound 1.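

In this assay the effect of the atom joining the hexyl chain to the shared core can now be read on its own: with the chain kept, hexylamino in place of hexyloxy gives a 19-fold lower number from compound 1 to compound 3 (1.27 log units; beyond the scatter) and so moves the number far at this position. Against the much shorter methylsulfanyl, hexylamino still goes with an 8.5-fold higher number from compound 2 to compound 3 (0.93 log units; beyond the scatter) even with this nitrogen in place, though that change alters the chain and the joining atom together. Nothing measured here explains either step.

The compounds shown leave open how much of the remaining step belongs to chain length, which a hexylsulfanyl or a methylamino group on this aromatic carbon could separate. They also leave open whether chains between methyl and hexyl, or an unsubstituted amine, would give numbers nearer those of compound 2.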